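The compounds below may be only part of what the source reports. "The series", "measured", "known", "first", "only" and "open" are said of these compounds alone.

Of the compounds shown here, three that share one core have been measured in a physicochemical assay for solubility, in phosphate buffer, measured as kinetic solubility; a lower number here means a less soluble compound, a higher number a more soluble compound. Compound 1 `CC(C)(/C=C1\OC(=O)NC1=O)c1ccc(-c2ccc3cccc(F)c3c2)[nH]c1=O` gives 36100 nM, compound 2 `CCC(CC)C(/C=C1\OC(=O)NC1=O)c1ccc(-c2ccc3cccc(F)c3c2)[nH]c1=O` gives 33700 nM, and compound 3 `CC(C)C(c1ccc(-c2ccc3cccc(F)c3c2)[nH]c1=O)C1C(=O)NC(=O)N1C` gives 17900 nM. Compound 3 has the lowest of the three numbers, yet its gaps to compound 2 and to compound 1 both lie within the scatter, so nothing sets it apart from the other two. Compound 4 `CC(C)C(c1ccc(-c2ccc3cccc(F)c3c2)[nH]c1=O)C1NC(=O)NC1=O` has not yet been measured in this assay; it differs from compound 3 by hydrogen in place of methyl on an amide-type nitrogen in a ring. For the measured compounds named here, no step between measured compounds is known for this change, so its size cannot be read from the data. Compound 4 is expected to give 20000 nM, in a range from 9000 nM to 45000 nM. The step of a 1.1-fold higher number from compound 3 to compound 4 (0.05 log units; within the scatter) is expected to stay within the scatter.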

Compound 4, solubility: 10600 nM
Beside the measured number, compound 4's estimate is 1.9-fold (0.28 log units) above it; low and high end bracket the measured number.
By their numbers in this assay, from the lowest: compounds 4, 3, 2 and 1 (each within the scatter of the next, the first and the last beyond it).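

In this assay, for the compounds shown here, the change gives a 1.7-fold lower number from compound 3 to compound 4 (0.23 log units; within the scatter), the first reading of hydrogen in place of methyl on this amide-type nitrogen in a ring. The methyl of the 3-methyl-2,5-dioxoimidazolidin-4-yl group can thus be exchanged for hydrogen without a step beyond the scatter in this pair. Nothing available accounts for the size of this step.

On these data alone, this reading rests on a single pair, so whether it holds with another part of the molecule changed stays open. Also open, as far as these compounds go, is what an ethyl group, a longer chain or a chain ending in an amine or a carboxylic acid would give on this nitrogen.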